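The compounds below may be only part of what the source reports. "The series", "measured", "known", "first", "only" and "open" are said of these compounds alone.

Compound 1 `Oc1ccc(/C=N\NC(=S)NC2CCCCC2)c(O)c1` and compound 2 `COc1ccc(/C=N\NC(=S)NC2CCCCC2)cc1OC` share the same core and were both tested in a functional assay on MCF7 cells (Homo sapiens) for inhibition, read by WST assay, with a stated time of 48 h; a higher number here means a weaker inhibitor, a lower number a stronger inhibitor. Compound 1 gives 105000 nM, and compound 2 gives 99200 nM, a gap that lies within the scatter, so the two cannot be told apart. Compound 3 `Oc1ccc(/C=N\NC(=S)NC2CCCCC2)cc1` differs from compound 1 by hydrogen in place of hydroxy on an aromatic carbon. Among the measured compounds shown here, no measured pair shows this change, so the step from compound 1 to compound 3 is expected to stay within the scatter, in no clear direction, as a 1.1-fold lower number from compound 1 to compound 3 (0.02 log units; within the scatter). Compound 3 is therefore estimated at 100000 nM in this assay, within 40000 nM to 250000 nM.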

Compound 3, half-maximal inhibitory concentration: 50400 nM
Estimate against measurement, compound 3: 2.0-fold (0.30 log units) above; the range from low to high includes it.
By their numbers in this assay, from the lowest: compounds 3, 2 and 1 (each within the scatter of the next, the first and the last beyond it).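

Putting hydrogen in place of the hydroxy group ortho to a large group gives a 2.1-fold lower number from compound 1 to compound 3 (0.32 log units; beyond the scatter) in this assay, so compound 3 is the stronger inhibitor of this pair. This shows that the group at this position on the aromatic ring can shift the number by a modest amount, and that this hydroxy group is not required for inhibition. No measurement shown here accounts for the step.

Going by these compounds, whether an amine or a fluorine atom at this position would lower the number further remains open. On these data alone, the role of the remaining hydroxy group also remains open.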